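A few compounds are considered here, and "the series" means these few. Any claim that something is new, unique, unknown or untested is made for them only; others in the source may bear on it.

Compound 1, whose structure is `COc1ccccc1NC(=O)Oc1cc(=O)n(CCCO)c2c1CC(CC=C(C)C)C(C)(C)C2`, is a carbamate built on a shared core. In a functional assay on PANC-1 cells (Homo sapiens) for inhibition, read by MTT assay, with a stated time of 24 h, tested at 10 uM (on this read-out lower numbers stand for less inhibition and higher numbers for more inhibition at the one concentration tested (going by the name of the read-out)), compound 1 gives 71.1%, the second highest of three numbers measured here. Its two neighbours differ from it only in the aryl group on an amide-type nitrogen. Compound 2, `CC(C)=CCC1Cc2c(OC(=O)Nc3ccc(F)c(Cl)c3)cc(=O)n(CCCO)c2CC1(C)C`, gives 79.8%, and the step of a number 8.7 percentage points higher from compound 1 to compound 2 (within the scatter) stays within the usual scatter. Compound 3, `CC(C)=CCC1Cc2c(OC(=O)Nc3ccc(Cl)c(Cl)c3)cc(=O)n(CCCO)c2CC1(C)C`, gives 61.4%, and the step of a number 9.7 percentage points lower from compound 1 to compound 3 (within the scatter) likewise stays within the scatter. Between these two neighbours the step of a number 18.4 percentage points lower from compound 2 to compound 3 (beyond the scatter) is the only one that goes beyond the scatter.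

Compound 4, `COc1ccccc1NC(=O)Oc1cc(=O)n(CCCO)c2c1CC(C/C=C(\C)CCC=C(C)C)C(C)(C)C2`, keeps the 2-methoxyphenyl carbamate of compound 1 and changes the side chain instead: 3-methylbut-2-en-1-yl in place of hydrogen on a saturated chain carbon bound to a double-bonded chain carbon. For the measured compounds named here, none of the measured steps touches this part of the molecule, so there is no direct guide to how the chain length matters. With nothing pointing in either direction, the step of a number 1.1 percentage points lower from compound 1 to compound 4 (within the scatter) is expected to stay within the scatter. Compound 4 is therefore estimated to give about 70%, somewhere between 52% and 86%.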

Compound 4, a percentage reported as inhibition, at one concentration (the size of the read-out at that concentration, not a potency): 53%
Compound 4: middle estimate off by 17 percentage points, on the high side; the range from low to high includes it.
By their numbers in this assay, from the lowest: compounds 4, 3, 1 and 2 (each within the scatter of the next, the first and the last beyond it).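

In this assay, the longer 3,7-dimethylocta-2,6-dien-1-yl chain in place of the 3-methylbut-2-en-1-yl chain gives a number 18.1 percentage points lower from compound 1 to compound 4 (beyond the scatter). For the compounds shown here, the side chain, the same throughout the earlier compounds, therefore matters here: with the 2-methoxyphenyl carbamate held fixed, this one change moves the number beyond the scatter, which neither aryl swap starting from compound 1 did. Nothing measured here explains why the longer chain goes with less inhibition.

As far as these compounds go, whether the same chain would bring a similar step on the 3-chloro-4-fluorophenyl carbamate of compound 2 stays open. So does how a saturated chain such as hexyl, or a chain ending in an amine, would read at this position.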